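A few compounds are considered here, and "the series" means these few. Any claim that something is new, unique, unknown or untested is made for them only; others in the source may bear on it.

Compound 1 `CC(C)=CCCN(C)C1CCN(CCCc2c[nH]c3ccc(-n4cnnc4)cc23)CC1` gives 2.6 nM in an assay on CHO cells for displacement of a labelled ligand from 5-hydroxytryptamine receptor 1D (Homo sapiens); a lower number here means a stronger inhibitor, a higher number a weaker inhibitor.
Compound 2 `CN(Cc1ccco1)C1CCN(CCCc2c[nH]c3ccc(-n4cnnc4)cc23)CC1` gives 9.3 nM in this assay.
Compound 3 `CC(C)=CCN(C)C1CCN(CCCc2c[nH]c3ccc(-n4cnnc4)cc23)CC1` gives 0.5 nM in this assay.

Among the three measured compounds, compound 3 holds the lowest number, and both of its steps to the others lie beyond the scatter: it is a 5.2-fold lower number from compound 1 to compound 3 (0.72 log units; beyond the scatter) and a 19-fold lower number from compound 2 to compound 3 (1.27 log units; beyond the scatter). All three share the same core and differ only in the group on a saturated chain carbon bound to an amine nitrogen.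

Compound 4 `CC(=O)Nc1ccc(CN(C)C2CCN(CCCc3c[nH]c4ccc(-n5cnnc5)cc34)CC2)cc1` is not yet measured. It differs from compound 3 in one place: 4-acetamidophenyl in place of 2-methylprop-1-en-1-yl on a saturated chain carbon bound to an amine nitrogen. The group that enters carries an aromatic ring, a hydrogen-bond donor and a hydrogen-bond acceptor, none of which the group that leaves has.

For the measured compounds named here, two measured steps bear on this change. The step from compound 2 to compound 3 swapped an aromatic furan-2-yl for the same 2-methylprop-1-en-1-yl that now leaves, and it was a 19-fold lower number from compound 2 to compound 3 (1.27 log units; beyond the scatter), a large drop in the number. The step from compound 1 to compound 3 was smaller, a 5.2-fold lower number from compound 1 to compound 3 (0.72 log units; beyond the scatter). Moving back from the open-chain group to an aromatic ring is therefore expected to raise the number, and the larger, more polar group makes a step at least the size of the furan step plausible. Compound 4 is expected to give 10 nM, with a range of 2.5 nM to 40 nM; this would be a 20-fold higher number from compound 3 to compound 4 (1.30 log units; beyond the scatter).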

Compound 4, half-maximal inhibitory concentration: 19 nM
Compound 4: the middle estimate sits 1.9-fold (0.28 log units) below what was measured; the measured number falls inside the stated range.
By their numbers in this assay, from the lowest: compound 3; then compound 1; then compound 2; then compound 4.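

For the compounds shown here, compound 4 shows that this position still tolerates a much larger group than the earlier compounds carried: with the 4-acetamidophenyl group, in this assay there is a 38-fold higher number from compound 3 to compound 4 (1.58 log units; beyond the scatter) and the number stays measurable, yet this is the widest step among the four compounds. Going by these compounds alone, the new result also extends a pattern, with no compound among the four against it: the two compounds with an aromatic ring at this place, compound 2 and compound 4, both have higher numbers than the two with an open chain, as seen in a 7.3-fold higher number from compound 1 to compound 4 (0.86 log units; beyond the scatter) and in a 3.6-fold higher number from compound 1 to compound 2 (0.55 log units; beyond the scatter), while the two aromatic groups stay much closer to each other, with a 2.0-fold higher number from compound 2 to compound 4 (0.31 log units; beyond the scatter) as the modest gap. No measurement here accounts for any of these steps.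

With the ring and the acetamide entering together, the compounds shown cannot divide the rise between them, and a plain phenyl ring at this place would be the direct test. Also open, as far as these compounds go, is how a saturated cyclohexyl ring would compare with these aromatic groups, or how a primary amine or a carboxylic acid in place of the acetamide would change the number.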